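Hydroxy for fluoro on a cinnamamide TRPV1 inhibitor

A few compounds are considered here, and "the series" means these few. Any claim that something is new, unique, unknown or untested is made for them only; others in the source may bear on it.

Measured compounds:
compound 1 `O=C(/C=C/c1ccc(Cl)cc1)Nc1ccc2c(c1)OCCO2` with 250 nM
compound 2 `O=C(/C=C/c1ccc(F)cc1)Nc1ccc2c(c1)OCCO2` with 1000 nM

Two compounds share one core and differ only in the group on the aromatic carbon of the cinnamoyl ring. In a functional assay on CHO cells for inhibition of transient receptor potential cation channel subfamily V member 1 (Homo sapiens) (a higher number here means a weaker inhibitor, a lower number a stronger inhibitor), compound 1 gives 250 nM, and in this assay compound 2 gives 1000 nM. Among the compounds with values here, the one measured step, a 4.0-fold higher number from compound 1 to compound 2 (0.60 log units; beyond the scatter), puts compound 2 at the higher of the two numbers, a gap that lies beyond the scatter.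

Compound 3 `O=C(/C=C/c1ccc(O)cc1)Nc1ccc2c(c1)OCCO2` is the next member of the series. It differs from compound 2 by hydroxy in place of fluoro on an aromatic carbon. Within the data shown here, no measured step concerns a hydroxy group, so the only guidance is the step of a 4.0-fold higher number from compound 1 to compound 2 (0.60 log units; beyond the scatter), which shows that the group at this place matters to the number in this assay by a modest amount. Among the measured compounds shown here, the hydroxy compound has no close precedent among the measured pair, and the expectation therefore rests on that single step and carries a wide range.

Compound 3 is expected to give 2000 nM in this assay, between 500 nM and 8000 nM, which would mean an estimated step of a 2.0-fold higher number from compound 2 to compound 3 (0.30 log units; within the scatter).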

Compound 3, half-maximal inhibitory concentration: > 4000 nM
Compound 3: only a limit was reported; the forecaster's own chance of this, stated with the estimate: 10%; middle value at least 2.0-fold (0.30 log units) away from the limit.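

Hydroxy in place of fluoro on this aromatic carbon gives an at least 4.0-fold higher number from compound 2 to compound 3 (0.60 log units; beyond the scatter) and hydroxy in place of chloro gives an at least 16-fold higher number from compound 1 to compound 3 (1.20 log units; beyond the scatter) so the position proves far more sensitive than the halogen pair alone could show, where the one earlier step, a 4.0-fold higher number from compound 1 to compound 2 (0.60 log units; beyond the scatter) was only modest. Compound 3, the first of the series with a hydrogen-bond donor on this ring, is the weakest of the three, and the order at this place runs from chloro through fluoro to hydroxy. In this assay compound 3 is reported only as a limit and not as a number: the limit of > 4000 nM in this assay, at which 1 of the 3 values shown sits.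

How far compound 3 lies beyond that limit stays open, so the true size of both new steps is unknown, and the three compounds cannot tell why hydroxy costs so much here. Whether a methoxy group, which keeps the oxygen but loses its hydrogen, or an amine or a carboxylic acid at this place would behave like hydroxy, and whether bromo or a methyl group would track chloro, also remains unanswered.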